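The source may hold more compounds than are shown below. What is called first, only, known or untested is meant among the compounds shown, and "the series" means these compounds.

Compound 2 `C=CC1=C(C(=O)NC(C)(C)C)C(c2ccc(F)cc2)OC1` is one of two measured compounds built on the same core. In a functional assay on SW480 cells (Homo sapiens) for cytotoxicity, read by MTT assay, with a stated time of 24 h (on this read-out higher numbers stand for weaker inhibition and lower numbers for stronger inhibition), compound 2 gives > 100000 nM, which is a limit of the assay and not a number. Compound 1 `C=CC1=C(C(=O)NCc2ccc(C)cc2)C(c2ccc(F)cc2)OC1` carries 4-methylbenzyl where compound 2 carries tert-butyl on the amide-type nitrogen. In this assay compound 1 gives > 100000 nM, also a limit. The step that the two limits leave unreadable from compound 1 to compound 2 can therefore not be given a size. Both values sit at the limit of > 100000 nM in this assay, at which 2 of the 2 values shown sit.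

Compound 3 `C=CC1=C(C(=O)NCCCCC)C(c2ccc(F)cc2)OC1` differs from compound 2 by pentyl in place of tert-butyl on an amide-type nitrogen. For the measured compounds named here, the only measured step at that position is the one from compound 1 to compound 2, and it is unreadable, so no measured step tells how large a change to expect. The expectation is that compound 3 remains at the limit, so that a step that the limit leaves unreadable from compound 2 to compound 3 is expected to be no step beyond the scatter. Compound 3 is estimated to give 200000 nM, with a range from 60000 nM to 1000000 nM.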

Compound 3, half-maximal inhibitory concentration: > 100000 nM
Compound 3 ended at the assay's limit (the forecaster's own chance of this, stated with the estimate: 85%); the middle value is on the limit's open side.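

Compound 1, compound 2 and compound 3 all stop at a limit of the assay and not a number, so no step among them can be read: the limit of > 100000 nM in this assay, at which 3 of the 3 values shown sit.

The compounds shown leave open how far beyond that limit each one lies, and whether any group on the amide-type nitrogen gives a readable value in this assay.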